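From 4-methylphenyl to 2,5-dihydroxyphenyl on a shared core

The source may report more compounds than this note shows. Statements on the series, on what has been measured and on what is new or still open speak of the compounds shown alone.

Compound 1 `COc1cc(OC)c(OC)cc1/C=C/C(=O)c1ccccc1`: 2.23 ug/mL
Compound 2 `COc1cc(OC)c(OC)cc1/C=C/C(=O)c1ccc(C)cc1`: 2.24 ug/mL

In a functional assay on cells (Erythrocyte, Rattus norvegicus) for inhibition, read by hemolysis, with a stated time of 1 h (a lower number here means a stronger inhibitor, a higher number a weaker inhibitor), compound 2 gives 2.24 ug/mL. Among the measured compounds shown here, its only measured neighbour, compound 1, gives 2.23 ug/mL, so the two sit level within the scatter of repeated measurements. The next structure, compound 3 `COc1cc(OC)c(OC)cc1/C=C/C(=O)c1cc(O)ccc1O`, keeps the shared core but exchanges the group on the carbonyl carbon: 2,5-dihydroxyphenyl in place of 4-methylphenyl on a carbonyl carbon.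

For the measured compounds named here, only one measured step bears on this change: a 1.0-fold higher number from compound 1 to compound 2 (0.00 log units; within the scatter). That step put methyl in place of hydrogen on an aromatic carbon, and it stayed within the scatter. Going by the values given here, it is a much smaller edit than the one in compound 3, however, and no measured compound carries a 2,5-dihydroxyphenyl group. The data therefore point in no direction, and the best guess is no shift beyond the scatter, held with wide uncertainty. The expected size of the move is a 1.0-fold higher number from compound 2 to compound 3 (0.01 log units; within the scatter). Compound 3 is estimated at 2.3 ug/mL, with an expected range from 0.9 ug/mL to 6 ug/mL.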

Compound 3, half-maximal inhibitory concentration: 2.1 ug/mL
Compound 3: the middle estimate sits 1.1-fold (0.04 log units) above what was measured, and the stated range covers the measured number.
By their numbers in this assay, from the lowest: compounds 3, 1 and 2 (each within the scatter of the next).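

In this assay the step to 2,5-dihydroxyphenyl reads a 1.1-fold lower number from compound 2 to compound 3 (0.03 log units; within the scatter) and, measured from the unsubstituted phenyl, a 1.1-fold lower number from compound 1 to compound 3 (0.03 log units; within the scatter) so both comparisons stay within the scatter. Until now, the group on the carbonyl carbon had been tested only with the small swap of a hydrogen for a methyl, whereas this much larger change brings in hydrogen-bond donors and acceptors, which 4-methylphenyl lacks, and still leaves the number level. No measurement at hand accounts for this flat result.

As far as these compounds go, all three compounds keep a six-membered aromatic carbon ring on the carbonyl carbon, so it remains open whether the number would also hold with an amine, a carboxylic acid or a longer alkyl chain there instead of that ring. From the compounds shown here alone, it is also open whether a single hydroxyl group on the ring would behave like the 2,5-dihydroxyphenyl group, and whether the same level result would survive a change to the shared core itself.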